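Moving the methyl around the aryl urea ring

The source may report more compounds than this note shows. Statements on the series, on what has been measured and on what is new or still open speak of the compounds shown alone.

The measured compounds and their values:
compound 1 `O=C(Nc1cccc(C(F)(F)F)c1)N[C@H]1CC[C@H](Oc2cccc(C(F)(F)F)c2)CC1` gives 1300 nM;
compound 2 `Cc1cccc(NC(=O)N[C@H]2CC[C@H](Oc3ccc(F)cc3)CC2)c1` gives 14400 nM;
compound 3 `COC(=O)c1cccc(NC(=O)N[C@H]2CC[C@H](Oc3ccc(F)cc3)CC2)c1` gives 9200 nM.

These three numbers come from a functional assay on CRL2813 cells (Homo sapiens) for cytotoxicity, read by sulforhodamine B assay, with a stated time of 5 days; a lower number here means a stronger inhibitor, a higher number a weaker inhibitor. Compound 2 has the highest number of the three; its nearest neighbour is compound 3, and the step of a 1.6-fold lower number from compound 2 to compound 3 (0.19 log units; within the scatter) lies within the scatter, so the two cannot be ranked against each other. Compound 1 sits far lower, by an amount beyond the scatter, so compound 1 is clearly the stronger inhibitor of the three.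

The step now followed leads from compound 2 to compound 4 `Cc1ccccc1NC(=O)N[C@H]1CC[C@H](Oc2ccc(F)cc2)CC1`, which has not yet been measured. The two share every atom and differ only in how they are joined: 2-methylphenyl in place of 3-methylphenyl on an amide-type nitrogen. The methyl group stays, but it moves to a different carbon of the same ring.

For the measured compounds named here, no measured step describes this kind of change. Going by the values given here, the only measured step that touches this ring, the step from compound 2 to compound 3, swaps the methyl for a different group at the same carbon and stays within the scatter; it says nothing about moving a group. With no guide, compound 4 is expected to land close to compound 2, with the step of a 1.0-fold higher number from compound 2 to compound 4 (0.02 log units; within the scatter) expected to stay within the scatter. Compound 4 is therefore estimated at 15000 nM, with a range from 6000 nM to 40000 nM.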

Compound 4, half-maximal inhibitory concentration: > 20000 nM
Compound 4: a limit, no number; the forecaster's own chance of this, stated with the estimate: 15%; middle value at least 1.3-fold (0.12 log units) away from the limit.
By their numbers in this assay, from the lowest: compound 1; then compounds 3 and 2 (each within the scatter of the next). At a limit, above all of these: compound 4.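

Compound 4 reads as a limit of the assay and not a number, the only such reading among the compounds shown: the limit of > 20000 nM in this assay, at which 1 of the 4 values shown sits. Moving the methyl on the ring attached to the amide-type nitrogen, so that 2-methylphenyl stands in place of 3-methylphenyl, gives an at least 1.3-fold higher number from compound 2 to compound 4 (0.14 log units; that floor lies within the scatter); only a floor for this step is known, and because that floor lies within the scatter, the true size of the step remains unknown. The earlier compounds shown here showed only a swap of one group for another at a single carbon of this ring, whereas this pair tests a move of the same group, and in this assay the move produces no lower number.

The compounds shown leave open how a carboxylic acid or an amine would read in place of the methyl, at either of these two carbons of the ring. They also leave open which of its features set compound 1 apart, as it differs from the other compounds in more than one place and offers no single change to follow.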